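Pyrazole-linked enones: cytotoxicity notes toward compound 4

The source may hold more compounds than are shown below. What is called first, only, known or untested is meant among the compounds shown, and "the series" means these compounds.

Measured so far:
- compound 1, `COc1cc(-c2cc(/C=C/C(=O)c3ccc(N)cc3)[nH]n2)cc(OC)c1OC`: -38%
- compound 2, `COc1ccc(-c2cc(/C=C/C(=O)c3ccc(OC)c(OC)c3)[nH]n2)cc1`: -28%
- compound 3, `COc1ccc(-c2cc(/C=C/C(=O)c3ccc(N)cc3)[nH]n2)cc1OC`: 28%

In a functional assay on T47D cells (Homo sapiens) for cytotoxicity, read by sulforhodamine B assay, with a stated time of 48 h, tested at 10 uM (a lower number here means a stronger effect, a higher number a weaker effect of the compound at the concentration tested), compound 1 gives the lowest of the three numbers. Compound 2 sits nearest, a number within the scatter of compound 1, so no order between the two is claimed. Compound 3 is furthest away: the step of a number 66 percentage points higher from compound 1 to compound 3 (beyond the scatter) is large and goes beyond the scatter, and it concerns a hydrogen in place of methoxy on an aromatic carbon of the ring attached to the shared core, not the ring on the carbonyl carbon.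

Compound 4, `COc1cc(-c2cc(/C=C/C(=O)c3ccc(F)c(F)c3)[nH]n2)cc(OC)c1OC`, is not yet measured. It differs from compound 1 as follows: 3,4-difluorophenyl in place of 4-aminophenyl on a carbonyl carbon. The 3,4-difluorophenyl enters where the 4-aminophenyl leaves, on the carbonyl carbon whose other neighbour is the double-bonded chain carbon.

Among the compounds with values here, no measured step touches the ring on the carbonyl carbon while holding the rest of the molecule fixed; compound 2 carries a 3,4-dimethoxyphenyl there but also a different ring on the core, so its value only shows that such a variant stays within the scatter of compound 1. The step of a number 66 percentage points higher from compound 1 to compound 3 (beyond the scatter) bears on a different position and gives no direction here. The estimate for compound 4 is therefore a step of a number 13 percentage points higher from compound 1 to compound 4 (beyond the scatter), expected to stay within the scatter, with a wide range to cover the unknown. Compound 4 is expected to give -25%, between -60% and 20%.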

Compound 4, a percentage reported as activity, at one concentration (the size of the read-out at that concentration, not a potency): 9%
Estimate against measurement, compound 4: 34 percentage points below, within the range that was stated.
By their numbers in this assay, from the lowest: compounds 1 and 2 (each within the scatter of the next); then compound 4; then compound 3.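

In this assay, the ring on the carbonyl carbon now has a step with the rest of the molecule held fixed: a number 47 percentage points higher from compound 1 to compound 4 (beyond the scatter) for 3,4-difluorophenyl in place of 4-aminophenyl. Within the data shown here, this position therefore matters to the read-out, which the earlier compounds could not show, since compound 2 also differs from compound 1 at the ring on the core. The number also moves from the negative to the positive side, with compound 1 at -38% and compound 4 at 9%, so both single-place steps from compound 1 now lead to a higher number, one at each of the two rings, and the 4-aminophenyl form of compound 1 stands out against both neighbours.

The compounds shown leave open whether the difference follows from losing the 4-aminophenyl or from gaining the 3,4-difluorophenyl, which a plain phenyl, or a ring bearing a hydroxyl or dimethylamino group, on the carbonyl carbon would help to separate, and whether the same exchange gives a similar step on the core of compound 3. Nothing measured here ties this step to any cause.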